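The source may hold more compounds than are shown below. What is called first, only, known or untested is meant among the compounds shown, and "the series" means these compounds.

The series shares one core, with an aryl group on a carbon with a double bond to nitrogen as the varied part. Compound 1 `COc1ccc(OC)c(/C=N/NC(=O)Nc2ccc(Oc3ccnc(-c4nncn4CCN(C)C)c3)c(F)c2)c1` has "not determined" (no result reported) in an ADME assay on WI-38 cells (Homo sapiens) for cytotoxicity, read by MTT assay, with a stated time of 72 h (a lower number here means a stronger inhibitor, a higher number a weaker inhibitor), that is, no result reported. Compound 2 `CN(C)CCn1cnnc1-c1cc(Oc2ccc(NC(=O)N/N=C/c3ccc(Cl)cc3)cc2F)ccn1` gives 1870 nM in this assay, and compound 3 `CN(C)CCn1cnnc1-c1cc(Oc2ccc(NC(=O)N/N=C/c3ccccc3O[N+](=O)[O-])cc2F)ccn1` gives 6860 nM. Compound 3 therefore stands at the higher of the two numbers; the only step shown, a 3.7-fold higher number from compound 2 to compound 3 (0.56 log units; beyond the scatter), is modest and beyond the scatter.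

Compound 4 `Cc1cc(/C=N/NC(=O)Nc2ccc(Oc3ccnc(-c4nncn4CCN(C)C)c3)c(F)c2)cc(C)c1O` differs from compound 3 at that same carbon: 4-hydroxy-3,5-dimethylphenyl in place of 2-(nitrooxy)phenyl on a carbon with a double bond to nitrogen. Within the data shown here, no measured step covers this exact exchange. Among the measured compounds shown here, the one step that bears on it, a 3.7-fold higher number from compound 2 to compound 3 (0.56 log units; beyond the scatter), shows that swapping the aryl group at this carbon moves the number by a modest amount, and its direction for a new group cannot be read from a single precedent. Without a closer comparison, the expectation is that compound 4 stays near compound 3, with a range wide enough to cover a modest move either way. The expected value of compound 4 in this assay is 5000 nM, within 1500 nM to 16000 nM. The step this estimate implies, a 1.4-fold lower number from compound 3 to compound 4 (0.14 log units; within the scatter), is expected to fall within the scatter.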

Compound 4, half-maximal inhibitory concentration: 3610 nM
Compound 4: the middle estimate sits 1.4-fold (0.14 log units) above what was measured; measured number inside the range.
By their numbers in this assay, from the lowest: compounds 2, 4 and 3 (each within the scatter of the next, the first and the last beyond it).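

At the carbon with a double bond to nitrogen, 4-hydroxy-3,5-dimethylphenyl in place of 2-(nitrooxy)phenyl gives, in this assay, a 1.9-fold lower number from compound 3 to compound 4 (0.28 log units; within the scatter), and 4-hydroxy-3,5-dimethylphenyl in place of 4-chlorophenyl gives a 1.9-fold higher number from compound 2 to compound 4 (0.29 log units; within the scatter), so this third aryl group cannot be separated from either of the earlier two. The new aryl group shares only the six-membered aromatic ring of carbon with the group it replaces, and even this exchange stays within the scatter, while the gap between compound 2 and compound 3 remains the only difference beyond it; at this position, a large change in the substituents on the aryl group need not give a separable change in the number. Nothing measured here explains these numbers.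

Open, as far as these compounds go, is whether an aryl group carrying an amine or a carboxylic acid at this carbon would stand beyond the scatter of all three numbers. Also open is how the hydroxy group and the two methyl groups of compound 4 each contribute on their own, since they enter together in every step shown.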